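The compounds below may be only part of what the source reports. "The series", "measured", "known", "first", "only" and "open" are said of these compounds alone.

Compound 1, `O=S(=O)(c1ccc(-c2ccc3nncc(Nc4ccc(OCc5ccccc5)c(Cl)c4)c3c2)cc1)N1CCOCC1`: > 15 uM in a toxicity assay on HepG2 cells (Homo sapiens) for cytotoxicity, read by MTT assay, with a stated time of 48 h; a higher number here means that more compound is tolerated, a lower number that less compound is tolerated
Compound 2, `CN1CCN(S(=O)(=O)c2ccc(-c3ccc4c(Nc5ccc(OCc6cccc(F)c6)c(Cl)c5)nccc4c3)cc2)CC1`: > 15 uM in this assay
Compound 3, `O=S(=O)(c1ccc(C2=CC3C(Nc4ccc(OCc5ccccc5)c(Cl)c4)=NC=NC3S2)cc1)N1CCOCC1`: > 15 uM in this assay

In this assay compound 2 is recorded only as a limit, > 15 uM, not as a number. The same is true of compound 1, whose result in this assay is the limit > 15 uM. Compound 3 likewise stops at the limit > 15 uM in this assay. Within the data shown here, every result so far therefore sits at the same point, (the limit of > 15 uM in this assay, at which 3 of the 3 values shown sit), and no step between measured compounds can be drawn.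

Compound 4, `CN1CCCN(S(=O)(=O)c2ccc(-c3ccc4c(Nc5ccc(OCc6cccc(F)c6)c(Cl)c5)nccc4c3)cc2)CC1`, differs from compound 2 in one place: 4-methyl-1,4-diazepan-1-yl in place of 4-methylpiperazin-1-yl on a sulfonyl sulfur. Among the measured compounds shown here, because the three values shown all rest on (the limit of > 15 uM in this assay, at which 3 of the 3 values shown sit), there is no measured step on which to size an effect of this change, and no movement beyond the usual scatter is expected from compound 2 to compound 4 in this assay. Compound 4 is accordingly estimated at 25 uM in this assay, within 10 uM to 60 uM, with the step that the limit leaves unreadable from compound 2 to compound 4 expected to be negligible and the result most likely to be reported again as a limit.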

Compound 4, half-maximal toxic concentration: > 15 uM
Compound 4: a limit, no number; the forecaster's own chance of this, stated with the estimate: 80%; the middle value lies beyond the limit too.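

Compound 2 and compound 4 both stop at a limit in this assay, and no step can be read between them: the limit of > 15 uM in this assay, at which 4 of the 4 values shown sit. The compounds shown leave open at what concentration any of them would reach the half-maximal toxic effect in this assay.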